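Sulfonamide to methyl sulfone on a CRTH2 antagonist scaffold

The source may hold more compounds than are shown below. What is called first, only, known or untested is meant among the compounds shown, and "the series" means these compounds.

Measured so far:
compound 1, `CNS(=O)(=O)c1ccc(C)c(C#Cc2cc(Cl)ccc2OCC(=O)O)c1`, 10 nM
compound 2, `Cc1ccc(S(=O)(=O)NC(C)(C)C)cc1C#Cc1cc(Cl)ccc1OCC(=O)O`, 5 nM

Compound 2 has the lower of the two numbers in an assay on CHO cells for displacement of a labelled ligand from prostaglandin D2 receptor 2 (Homo sapiens), read by scintillation counting (on this read-out higher numbers stand for weaker inhibition and lower numbers for stronger inhibition), but the measured step between them is a 2.0-fold lower number from compound 1 to compound 2 (0.30 log units; within the scatter), so the two cannot be told apart. Compound 3, `Cc1ccc(S(C)(=O)=O)cc1C#Cc1cc(Cl)ccc1OCC(=O)O`, is the next step: methyl in place of (tert-butyl)amino on a sulfonyl sulfur. For the measured compounds named here, the only measured step, from compound 1 to compound 2, changed a group on the same sulfur-bearing part of the molecule and stayed within the scatter; it says nothing directly about removing the nitrogen and its hydrogen-bond donor, which is what the step to compound 3 does. With so little to lean on, a small loss is expected rather than a gain, and the estimate for compound 3 in this assay is 15 nM, within 4 nM to 60 nM, an expected step of a 3.0-fold higher number from compound 2 to compound 3 (0.48 log units; beyond the scatter).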

Compound 3, inhibition constant: 5 nM
Compound 3: the middle estimate sits 3.0-fold (0.48 log units) above what was measured; measured number inside the range.
By their numbers in this assay, from the lowest: compounds 2, 3 and 1 (each within the scatter of the next).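

In this assay, removing the nitrogen from the group on the sulfonyl sulfur leaves the number unmoved, with no change at the digits printed from compound 2 to compound 3 (within the scatter) and a 2.0-fold lower number from compound 1 to compound 3 (0.30 log units; within the scatter). The earlier pair showed only that the substituent on that nitrogen could be exchanged, whereas these steps show that neither the nitrogen nor its hydrogen is needed to keep the number in this range, and that a plain methyl on the sulfur serves as well as (tert-butyl)amino. No supporting measurement is available to explain this tolerance.

The compounds shown leave open how far the tolerance reaches, such as what a longer chain like n-propyl, or a cyclic amine like morpholine, would do on the same sulfur. They also do not say whether the three compounds would stay this close in any read-out other than this assay.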